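Lengthening a Methyl Toward Propyl: Expecting Compound 4

This account rests on a few compounds, and the source may have more. Where it says the series, first, only, none or still open, it means among the compounds named here.

Of the compounds shown here, three sharing a core have been measured in a functional assay on ACHN cells (Homo sapiens) for cytotoxicity, read by sulforhodamine B assay, tested at 10 uM; a lower number here means less inhibition, a higher number more inhibition at the concentration tested (going by the name of the read-out). Compound 1 `CC(C)(C)c1ccc(Cn2cc(-c3cn([C@H]4C[C@H](O)[C@@H](CO)O4)c(=O)[nH]c3=O)nn2)cc1` gives 102%, compound 2 `CCCCc1ccc(-c2cc(-c3cn([C@H]4C[C@H](OC(C)=O)[C@@H](COC(C)=O)O4)c(=O)[nH]c3=O)on2)cc1` gives 80.5%, and compound 3 `CC(=O)OC[C@H]1O[C@@H](n2cc(-c3cc(C)no3)c(=O)[nH]c2=O)C[C@@H]1OC(C)=O` gives 96.4%. Compound 3 thus stands second highest of the three: its value lies within the scatter of compound 1, while compound 2 sits beyond the scatter below it. Among the measured compounds shown here, the one step measured between neighbouring structures, a number 15.9 percentage points higher from compound 2 to compound 3 (beyond the scatter), came with methyl in place of 4-butylphenyl on an aromatic carbon, so the smaller group here went with the higher inhibition.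

Compound 4 `CCCc1cc(-c2cn([C@H]3C[C@H](OC(C)=O)[C@@H](COC(C)=O)O3)c(=O)[nH]c2=O)on1` differs from compound 3 by ethyl in place of hydrogen on a saturated chain carbon bound to an aromatic carbon. For the measured compounds named here, this grows the methyl to propyl, a move part of the way back toward the larger group of compound 2, so the only relevant step suggests at most a modest fall, likely near the scatter. For compound 4 the estimate in this assay is 91%, within 76% to 102%. That corresponds to an expected step of a number 5.4 percentage points lower from compound 3 to compound 4 (within the scatter).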

Compound 4, a percentage reported as inhibition, at one concentration (the size of the read-out at that concentration, not a potency): 99.5%
Compound 4: middle estimate off by 8.5 percentage points, on the low side; the measured number falls inside the stated range.
By their numbers in this assay, from the lowest: compound 2; then compounds 3, 4 and 1 (each within the scatter of the next).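

In this assay, lengthening methyl to propyl makes no difference that can be told from the scatter, a number 3.1 percentage points higher from compound 3 to compound 4 (within the scatter), so this spot accepts a chain at least as long as propyl. Set against compound 2, propyl behaves as methyl did, a number 19 percentage points higher from compound 2 to compound 4 (beyond the scatter), so the lower reading of compound 2 is not shared by every group larger than methyl, but goes with 4-butylphenyl among the groups seen so far. Nothing available here explains why propyl and 4-butylphenyl differ.

On these data alone, it remains open where between propyl and 4-butylphenyl the reading starts to fall. A longer chain such as hexyl, or a phenyl ring without its butyl group, would show whether chain length or the ring goes with the lower number.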